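Methyl in place of amino on compound 3

A few compounds are considered here, and "the series" means these few. Any claim that something is new, unique, unknown or untested is made for them only; others in the source may bear on it.

Three compounds sharing one core have numbers in a physicochemical assay for solubility, at pH 7; on this read-out higher numbers stand for higher solubility and lower numbers for lower solubility. Compound 1 `OC[C@@H](O[C@H]1CCCN(Cc2ncc[nH]2)[C@H]1c1ccccc1)c1cc(Cl)cc(Cl)c1`, which carries 1H-imidazol-2-yl on a saturated chain carbon bound to the ring amine nitrogen, gives 120000 nM. Compound 2 `O=C(O)c1ccc(CN2CCC[C@H](O[C@H](CO)c3cc(Cl)cc(Cl)c3)[C@@H]2c2ccccc2)cc1`, with 4-carboxyphenyl in that place, gives 85000 nM. Compound 3 `Nc1cc(C(=O)O)ccc1CN1CCC[C@H](O[C@H](CO)c2cc(Cl)cc(Cl)c2)[C@@H]1c1ccccc1`, with 2-amino-4-carboxyphenyl there, gives 78000 nM. All three values lie within the scatter of one another, so compound 3 stands level with the other two.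

Compound 4 `Cc1cc(C(=O)O)ccc1CN1CCC[C@H](O[C@H](CO)c2cc(Cl)cc(Cl)c2)[C@@H]1c1ccccc1` has methyl in place of amino on an aromatic carbon, ortho to a large group and meta to a carboxy group: methyl in place of amino on an aromatic carbon. Going by the values given here, no measured pair makes this exact swap. The nearest evidence is the step that has amino in place of hydrogen on the same carbon, a 1.1-fold lower number from compound 2 to compound 3 (0.04 log units; within the scatter), and it stayed within the scatter. The larger replacements were no different, at a 1.4-fold lower number from compound 1 to compound 2 (0.15 log units; within the scatter) and a 1.5-fold lower number from compound 1 to compound 3 (0.19 log units; within the scatter). No step beyond the scatter is therefore expected here, and the estimate is a 1.1-fold lower number from compound 3 to compound 4 (0.05 log units; within the scatter). For compound 4 the expected value in this assay is 70000 nM, with an estimated range of 35000 nM to 140000 nM.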

Compound 4, solubility: 157000 nM
Estimate against measurement, compound 4: 2.2-fold (0.35 log units) below, outside the stated range (above it).
By their numbers in this assay, from the lowest: compounds 3, 2, 1 and 4 (each within the scatter of the next).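

In this assay this aromatic carbon, ortho to a large group and meta to a carboxy group, now has amino and methyl compared directly: the swap gives a 2.0-fold higher number from compound 3 to compound 4 (0.30 log units; within the scatter) and so makes no step beyond the scatter. Set against plain hydrogen on the same carbon, methyl gives a 1.8-fold higher number from compound 2 to compound 4 (0.27 log units; within the scatter) and, like amino, stays within the scatter, so hydrogen, amino and methyl at this place all read alike. The wider change to 4-carboxy-2-methylphenyl in place of 1H-imidazol-2-yl gives a 1.3-fold higher number from compound 1 to compound 4 (0.12 log units; within the scatter) and is no different, which leaves all four compounds level with one another on this read-out.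

Nothing shown offers a reason for these small differences, and none can be assigned to the groups themselves. Still open, going by these compounds, is whether another group on this carbon, such as hydroxyl, methoxy or a longer chain like ethyl, would take the number beyond the scatter, or whether this place simply leaves the number where it is whatever group it carries.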